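A Benzyl Group on the Shared Core

The source may report more compounds than this note shows. Statements on the series, on what has been measured and on what is new or still open speak of the compounds shown alone.

Measured in an ADME assay on A549 cells (Homo sapiens) for cytotoxicity, read by LDH release, with a stated time of 15 h; on this read-out lower numbers stand for higher toxicity in this test and higher numbers for lower toxicity in this test:
Compound 1 `CC(C)(C)OC(=O)N1CCC(CNc2ccc(NC(=O)c3cc(Cl)ccc3O)c(Cl)c2)CC1`: "not determined" (no result reported)
Compound 2 `CCCC(C)(C)Nc1ccc(NC(=O)c2cc(Cl)ccc2O)c(Cl)c1`: 23700 nM
Compound 3 `O=C(Nc1ccc(NCC2CCNCC2)cc1Cl)c1cc(Cl)ccc1O`: "not determined" (no result reported)

Compound 3 has no single number to stand on in this assay, and compound 1 is likewise without one. The series therefore offers just one numerical anchor, and compound 2 supplies it at 23700 nM. Compound 4 `O=C(Nc1ccc(NCc2ccccc2)cc1Cl)c1cc(Cl)ccc1O` has not yet been measured. The structural step is phenyl in place of piperidin-4-yl on a saturated chain carbon bound to a nitrogen on an aromatic ring, which places phenyl in place of piperidin-4-yl on a saturated chain carbon bound to a nitrogen on an aromatic ring. The same difference can be read as (piperidin-4-yl)methyl to benzyl. For the measured compounds named here, no measured pair shows what such a change does here, so the data give no basis for a direction. No shift beyond the usual scatter is expected from the only available reference, compound 2 at 23700 nM, although the uncertainty is wide. Compound 4 is expected at about 20000 nM, with an estimated range from 7000 nM to 50000 nM.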

Compound 4, half-maximal cytotoxic concentration: 81300 nM
Beside the measured number, compound 4's estimate is 4.1-fold (0.61 log units) below it, and the stated range ends below it.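

In this assay, the nitrogen on an aromatic ring carrying benzyl rather than 1,1-dimethylbutyl gives a 3.4-fold higher number from compound 2 to compound 4 (0.54 log units; beyond the scatter), so the group at this nitrogen can shift the read-out beyond the usual scatter, here toward lower toxicity in this test. The change from piperidin-4-yl to phenyl itself cannot be read, as compound 3 has no single number, and compound 1 has none either. Nothing available explains the rise seen with benzyl.

The compounds shown leave open whether a pyridyl ring or a phenyl ring carrying a carboxylic acid on the same saturated chain carbon would read like compound 4. They also leave open how a longer chain between that ring and the nitrogen would read.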